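The source may report more compounds than this note shows. Statements on the series, on what has been measured and on what is new or still open speak of the compounds shown alone.

Of the compounds shown here, two have numbers so far. Compound 1 `CCN(CC)S(=O)(=O)c1ccc(S(=O)(=O)N2CCC[C@@H](C(=O)NC3COC3)C2)cc1` gives 900 nM in a functional assay on MIA PaCa-2 cells (Homo sapiens) for inhibition, read by MTT assay, with a stated time of 3 days; a lower number here means a stronger inhibitor, a higher number a weaker inhibitor. Compound 2 `CCN(CC)S(=O)(=O)c1ccc(S(=O)(=O)N2CCC[C@@H](C(=O)NC)C2)cc1`, in this assay, gives 2000 nM, the higher of the two numbers, set apart from compound 1 by the step of a 2.2-fold higher number from compound 1 to compound 2 (0.35 log units; beyond the scatter). Among the compounds with values here, the only measured step thus concerns the substituent on the amide-type nitrogen and nothing else.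

Compound 3 `CCN(CC)S(=O)(=O)c1ccc(S(=O)(=O)N2CCC[C@@H](c3nc(C)no3)C2)cc1` is not yet measured. It differs from compound 2 in one place: 3-methyl-1,2,4-oxadiazol-5-yl in place of methylcarbamoyl on a saturated ring carbon. Within the data shown here, no measured step bears directly on this change; the step from compound 1 to compound 2 exchanges the group on the amide-type nitrogen while keeping the methylcarbamoyl group in place, whereas here the methylcarbamoyl group itself leaves and an aromatic ring enters on the saturated ring carbon. The direction of the step cannot be read from the numbers on hand, so the expectation is set near compound 2 with a wide range, and the expected step is a 1.3-fold lower number from compound 2 to compound 3 (0.12 log units; within the scatter). Compound 3 is estimated at 1500 nM in this assay, with a range from 400 nM to 6000 nM.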

Compound 3, half-maximal inhibitory concentration: 700 nM
For compound 3 the middle estimate is 2.1-fold (0.33 log units) above the measured one; low and high end bracket the measured number.
By their numbers in this assay, from the lowest: compounds 3 and 1 (each within the scatter of the next); then compound 2.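

Working notes on the saturated ring carbon, two ring bonds from the ring nitrogen: in this assay, this position accepts more than a carbamoyl group, since exchanging methylcarbamoyl for 3-methyl-1,2,4-oxadiazol-5-yl gives a 2.9-fold lower number from compound 2 to compound 3 (0.46 log units; beyond the scatter). The earlier step changed only the substituent on the amide-type nitrogen, whereas this one removes the whole amide, with its 1 hydrogen-bond donor, and shows that a five-membered aromatic ring with 0 hydrogen-bond donors can take its place without a higher number; the further comparison gives a 1.3-fold lower number from compound 1 to compound 3 (0.11 log units; within the scatter), so the oxadiazole and the (oxetan-3-yl)carbamoyl group are not separated in this assay. No measurement on hand accounts for either step.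

Open, going by these compounds, is how far the 3-methyl-1,2,4-oxadiazol-5-yl result extends to other groups at this carbon, such as a carboxylic acid, an aminomethyl group, or the same oxadiazole carrying an ethyl or cyclopropyl group in place of its methyl. Also open, on these data alone, is whether the step holds when the diethylsulfonamide part of the shared core is replaced, for instance by a piperidine sulfonamide.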